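The source may hold more compounds than are shown below. What is called first, only, known or untested is meant among the compounds shown, and "the series" means these compounds.

Measured so far in an ADME assay on A549 cells (Homo sapiens) for cytotoxicity, read by resazurin assay, with a stated time of 48 h; on this read-out higher numbers stand for lower toxicity in this test and lower numbers for higher toxicity in this test:
compound 1 `CC(=O)Nc1ccc(NC(=O)c2cc(Cl)ccc2O)c(Cl)c1` gives "not determined" (no result reported)
compound 2 `CCCCCCCCC(C)Nc1ccc(NC(=O)c2cc(Cl)ccc2O)c(Cl)c1` gives 21900 nM
compound 3 `O=C(Nc1ccc(NCC2CC2)cc1Cl)c1cc(Cl)ccc1O` gives 14400 nM

Compound 3 (14400 nM) stands within the usual scatter of compound 2 (21900 nM), and compound 1 offers no number for comparison. Compound 4 `O=C(Nc1ccc(N(CC2CC2)CC2CC2)cc1Cl)c1cc(Cl)ccc1O` differs from compound 3 by cyclopropylmethyl in place of hydrogen on a nitrogen on an aromatic ring and reads as cyclopropylmethyl in place of hydrogen on a nitrogen on an aromatic ring. Among the measured compounds shown here, no measured pair isolates such a change. Compound 2 (21900 nM) and compound 3 (14400 nM) carry different groups on that nitrogen yet stay within the scatter, so no step beyond the scatter is expected in this assay and no direction is favoured. The expected change is a 1.1-fold lower number from compound 3 to compound 4 (0.04 log units; within the scatter) and should stay small. For compound 4 the estimate is 13000 nM (expected range 5500 nM to 30000 nM).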

Compound 4, half-maximal cytotoxic concentration: 12800 nM
The estimate for compound 4 lay 1.0-fold (0.01 log units) above the measured number; the range from low to high includes it.
By their numbers in this assay, from the lowest: compounds 4, 3 and 2 (each within the scatter of the next).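

In this assay, among the compounds shown here, the step on this nitrogen is the first one that isolates a single change: a 1.1-fold lower number from compound 3 to compound 4 (0.05 log units; within the scatter). Going from (cyclopropylmethyl)amino to bis(cyclopropylmethyl)amino therefore removes the hydrogen on this nitrogen and adds a second cyclopropylmethyl, without taking the number beyond the scatter. No measurement at hand bears on why this step is so small. Open, as far as these compounds go, is whether a carboxylic acid or a morpholine group at this nitrogen would give a step beyond the scatter.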